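This account rests on a few compounds, and the source may have more. Where it says the series, first, only, none or still open, it means among the compounds named here.

Measured so far in an ADME assay on cells (Macrophage, Homo sapiens) for cytotoxicity, read by MTT assay, with a stated time of 24 h; on this read-out higher numbers stand for lower toxicity in this test and lower numbers for higher toxicity in this test:
Compound 1, `COc1ccc(/C=C/c2ncc([N+](=O)[O-])n2CC(C)O)cc1`, gives 560 nM.
Compound 2, `CC(O)Cn1c([N+](=O)[O-])cnc1/C=C/c1ccc(Br)cc1`, gives 550 nM.
Compound 3, `COc1cccc(/C=C/c2ncc([N+](=O)[O-])n2CC(C)O)c1`, gives 1300 nM.

Compound 1 and compound 2 differ only by bromo in place of methoxy on an aromatic carbon, and this change gave a 1.0-fold lower number from compound 1 to compound 2 (0.01 log units; within the scatter). Compound 3 has the same atoms as compound 1 joined differently; the difference between the two cores is not broken down here. Compound 3 stands highest of the three, beyond the scatter from both compound 1 and compound 2.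

Compound 4, `CC(O)Cn1c([N+](=O)[O-])cnc1/C=C/c1cccc(Br)c1`, is not yet measured in this assay. It differs from compound 3 by bromo in place of methoxy on an aromatic carbon. This is the same kind of change as that from compound 1 to compound 2, though in compound 1 the group sits para to a large group while in compound 3 it sits meta to a large group. Because a 1.0-fold lower number from compound 1 to compound 2 (0.01 log units; within the scatter) lay within the scatter, the step of no change at the digits printed from compound 3 to compound 4 (within the scatter) is expected to be small as well. Compound 4 is therefore estimated at 1300 nM, probably between 650 nM and 2600 nM.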

Compound 4, half-maximal cytotoxic concentration: 620 nM
Compound 4: middle estimate off by 2.1-fold (0.32 log units), on the high side, and the stated range ends above it.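

In this assay, bromo in place of methoxy gave a 2.1-fold lower number from compound 3 to compound 4 (0.32 log units; beyond the scatter), yet the step on this core does not separate from the step on the core of compound 1: the same change on two cores in this assay, a 1.0-fold lower number (0.01 log units; within the scatter) from compound 1 to compound 2 and a 2.1-fold lower number (0.32 log units; beyond the scatter) from compound 3 to compound 4, 2.1-fold (0.31 log units) apart, within the scatter of two such steps. The change therefore carries across these two cores as far as repeated measurements can tell, but two pairs show neither a firm dependence on the core nor a fixed size for the step. With bromo on both compounds, 3-bromophenyl in place of 4-bromophenyl gave a 1.1-fold higher number from compound 2 to compound 4 (0.05 log units; within the scatter).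

The compounds shown leave open whether a chloro group, an amine or a carboxylic acid in place of bromo would follow the same course on either core.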